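Swapping the Aryl Amine on a Shared Core

A few compounds are considered here, and "the series" means these few. Any claim that something is new, unique, unknown or untested is made for them only; others in the source may bear on it.

Compound 1 `Cc1n[nH]c2ccc(-c3nc4cnc(N5CCN(C)CC5)cn4c3Nc3ccccc3F)cc12` — in a functional assay on CWR22R cells (Homo sapiens) for inhibition, with a stated time of 120 h (on this read-out higher numbers stand for weaker inhibition and lower numbers for stronger inhibition), compound 1 gives "not determined" (no result reported).
Compound 2 `Cc1n[nH]c2ccc(-c3nc4cnc(N5CCN(C)CC5)cn4c3Nc3ccc(Br)cc3)cc12` — in this assay compound 2 gives "not determined" (no result reported).
Compound 3 `Cc1n[nH]c2ccc(-c3nc4cnc(N5CCN(C)CC5)cn4c3Nc3ccc(Cl)cc3F)cc12` — in this assay compound 3 gives 14100 nM.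

Compound 1 stands without a number: for compound 1, as for compound 2, no value was reported in this assay. For the measured compounds named here, the only measured point is compound 3, which in this assay gives 14100 nM, a weak inhibition on this read-out. The three measured compounds share one core and differ only in the aryl group carried on the amine nitrogen.

Compound 4 `Cc1n[nH]c2ccc(-c3nc4cnc(N5CCN(C)CC5)cn4c3Nc3ccc(F)c(Cl)c3)cc12` is the next member. It differs from compound 1 by one exchange: 3-chloro-4-fluorophenyl in place of 2-fluorophenyl on a nitrogen on an aromatic ring.

Going by the values given here, no step between two measured compounds with a single number exists, so the size and direction of this change cannot be read from the data. The one reference, compound 3, sits at a weak level in this assay, and a step of no more than the usual scatter from that level, in either direction, is expected. Compound 4 is therefore estimated to give 12000 nM in this assay, with a likely range from 3000 nM to 45000 nM.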

Compound 4, half-maximal inhibitory concentration: 14000 nM
Beside the measured number, compound 4's estimate is 1.2-fold (0.07 log units) below it; measured number inside the range.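

In this assay, for the compounds shown here, the exchange of 4-chloro-2-fluorophenyl for 3-chloro-4-fluorophenyl on the nitrogen gives a 1.0-fold lower number from compound 3 to compound 4 (0.00 log units; within the scatter), the first step in this set that can be read. Both groups carry one chlorine and one fluorine on a phenyl ring and differ only in where those two atoms sit, so for this one pair, rearranging them leaves the read-out within the usual scatter of repeated measurements; the exchange from compound 1 to compound 4 cannot be read, as no number stands for compound 1 or compound 2. Nothing on hand explains why this pair gives matching values.

Going by these compounds alone, with only two numbers, both from phenyl groups carrying the same two halogens, the set leaves open how the read-out responds to a different kind of group at this nitrogen, such as a phenyl ring bearing a methoxy group or a carboxylic acid, or a cyclohexyl ring in place of the aromatic ring. It also leaves open whether the level seen here holds once the shared core itself is changed, since every compound shown keeps that core intact.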